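This account rests on a few compounds, and the source may have more. Where it says the series, first, only, none or still open, it means among the compounds named here.

Measured compounds in a functional assay on SW480 cells (Homo sapiens) for cytotoxicity, read by MTT assay, with a stated time of 72 h; on this read-out higher numbers stand for weaker inhibition and lower numbers for stronger inhibition:
Compound 1 `O=c1cc(CSc2nc3ccccc3s2)oc2ccccc12` gives > 25000 nM.
Compound 2 `Cc1cc(C)n2nc(SCc3nnc(SCc4coc5ccccc5c4=O)n3-c3ccccc3)nc2n1` gives 12400 nM.
Compound 3 `Cc1cc(C)nc(SCc2cc(=O)c3ccccc3o2)n1` gives > 25000 nM.

The value of compound 1 in this assay is a limit of the assay, not a number. The value of compound 3 in this assay is likewise a limit. Only compound 2 returns a resolved number in this assay. Compound 1 therefore stands at the limit of > 25000 nM in this assay, at which 2 of the 3 values shown sit, with nothing beyond it resolved.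

Compound 4 `Cc1ccc2oc(CSc3nc4ccccc4s3)cc(=O)c2c1` differs from compound 1 by methyl in place of hydrogen on an aromatic carbon. Among the compounds with values here, no measured step in this set bears on such a change, so no step beyond the usual scatter is expected in this assay in either direction; the expected step that the limit leaves unreadable from compound 1 to compound 4 is essentially flat. Compound 4 is expected to return about 30000 nM, between 12000 nM and 80000 nM, most probably again as a limit.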

Compound 4, half-maximal inhibitory concentration: > 25000 nM
Compound 4: no number, only a limit (the forecaster's own chance of this, stated with the estimate: 75%); the middle value does not contradict the limit.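

Compound 1 and compound 4 both return only a limit in this assay, so no step can be read between them: the limit of > 25000 nM in this assay, at which 3 of the 4 values shown sit. On these data alone, whether methyl in place of hydrogen on an aromatic carbon changes the read-out for the core of compound 1 remains open.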